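Halogen swap on the phenol ring of compound 2

The source may report more compounds than this note shows. Statements on the series, on what has been measured and on what is new or still open speak of the compounds shown alone.

Within the data shown here, compound 1 `COc1ccc(-c2cc(-c3cc(OC)ccc3O)[nH]n2)cc1` is the one member with a numerical read-out: in an assay on isolated protein for inhibition of Polyunsaturated fatty acid lipoxygenase ALOX15 (Homo sapiens), read by spectrophotometry (on this read-out higher numbers stand for weaker inhibition and lower numbers for stronger inhibition), compound 1 gives 6000 nM. Compound 2 `Oc1ccc(Br)cc1-c1cc(-c2ccccc2Cl)[nH]n1` returns no number in this assay. Compound 2 gives > 50000 nM, which is a limit of the assay and not a measured value. Among the measured compounds shown here, compound 2 therefore stands at the limit of > 50000 nM in this assay, at which 1 of the 2 values shown sits, the weaker end of what the pair shows, while compound 1 holds the sole real number.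

Compound 3 `Oc1ccc(Cl)cc1-c1cc(-c2ccccc2Cl)[nH]n1` is the next candidate. It differs from compound 2 by chloro in place of bromo on an aromatic carbon. For the measured compounds named here, no measured pair shows this change, so nothing here sets its size. The rest of compound 2 is kept intact, and the expectation is that the step that the limit leaves unreadable from compound 2 to compound 3 in this assay is small, with no direction beyond the usual scatter. Since compound 2 already sits at the limit of > 50000 nM in this assay, at which 1 of the 2 values shown sits, compound 3 is expected to come back as a limit too, more likely than not. Expected for compound 3 in this assay: 60000 nM, within 20000 nM to 200000 nM.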

Compound 3, half-maximal inhibitory concentration: > 50000 nM
Compound 3: no number, only a limit (the forecaster's own chance of this, stated with the estimate: 75%); the middle value does not contradict the limit.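

In this assay compound 3 gives > 50000 nM, which is a limit of the assay and not a number. Compound 2 also stands at a limit, so no step can be read between compound 2 and compound 3. The compounds shown leave open what chloro in place of bromo on an aromatic carbon does in this assay.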